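Piperidine in place of proline on a sulfonamide

The compounds below may be only part of what the source reports. "The series", "measured", "known", "first", "only" and "open" are said of these compounds alone.

Measured compounds:
- compound 1, `CCn1nc(C(F)(F)F)cc1C(=O)Nc1ccc(S(=O)(=O)N2CCCCC2C)cc1`: 30000 nM
- compound 2, `O=C(O)c1ccccc1-n1nc(C(F)(F)F)cc1C(=O)Nc1ccc(S(=O)(=O)N2CCCC2)cc1`: "not determined" (no result reported)
- compound 3, `Cn1nc(C(F)(F)F)cc1C(=O)Nc1ccc(S(=O)(=O)N2CCC[C@H]2C(=O)O)cc1`: > 300000 nM

In an ADME assay on Vero cells (Chlorocebus sabaeus) for cytotoxicity, read by MTT assay (on this read-out higher numbers stand for lower toxicity in this test and lower numbers for higher toxicity in this test), compound 1 gives 30000 nM. Compound 2 has "not determined" (no result reported) in this assay. For compound 3 the assay reports only a limit, > 300000 nM; this is the limit of > 300000 nM in this assay, at which 1 of the 3 values shown sits, and it is the one entry among the three that gives no single number.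

Compound 4, `Cn1nc(C(F)(F)F)cc1C(=O)Nc1ccc(S(=O)(=O)N2CCCCC2CO)cc1`, is not yet measured. It differs from compound 3 in one place: 2-(hydroxymethyl)piperidin-1-yl in place of 2-carboxypyrrolidin-1-yl on a sulfonyl sulfur. No step between two measured compounds is available to calibrate this change, so the expected size rests on the two numbers shown. Compound 1, which also carries a piperidin-1-yl group on the sulfonyl sulfur, sits well inside the measurable range, while compound 3 stands at the limit. The step from compound 3 to compound 4 is therefore expected to move toward higher toxicity, estimated as an at least 3.0-fold lower number from compound 3 to compound 4 (0.47 log units; beyond the scatter), a step beyond the scatter. Compound 4 is expected to give about 100000 nM, within 30000 nM to 300000 nM.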

Compound 4, half-maximal cytotoxic concentration: 159000 nM
Beside the measured number, compound 4's estimate is 1.6-fold (0.20 log units) below it; measured number inside the range.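

In this assay, 2-(hydroxymethyl)piperidin-1-yl in place of 2-carboxypyrrolidin-1-yl on a sulfonyl sulfur gives an at least 1.8-fold lower number from compound 3 to compound 4 (0.27 log units; that floor lies within the scatter). Compound 4 gives a single number, so this change can now be placed on the measurable scale, but it is not shown to do more than the usual scatter of repeated measurements. That step is only a floor, as the value for compound 3 is a limit and not a number: the limit of > 300000 nM in this assay, at which 1 of the 4 values shown sits.

The ring size and the replacement of the carboxylic acid by a hydroxymethyl group change together here, and the compounds shown leave open which of the two carries the step. Also open, on these data alone, is how this assay would read a piperidine ring carrying a carboxylic acid, or one carrying an aminomethyl group.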